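Pyrazole series: acyl variation at the ring nitrogen

This account rests on a few compounds, and the source may have more. Where it says the series, first, only, none or still open, it means among the compounds named here.

Measured compounds in an assay on Sf9 cells for inhibition of mitogen-activated protein kinase kinase kinase 14 (Homo sapiens), read by ADP-Glo, with a stated time of 60 min; a lower number here means a stronger inhibitor, a higher number a weaker inhibitor:
compound 1, `Cc1[nH]nc(N)c1-c1cccc(OC(F)(F)F)c1`, > 100000 nM
compound 2, `Cc1[nH]nc(N)c1-c1cccc(C(F)(F)F)c1`, > 100000 nM
compound 3, `CCCC(=O)n1nc(C)c(-c2ccc(Cl)c(Cl)c2)c1N`, > 100000 nM

Each of the three values above is a limit of this assay and not a number. Compound 3, with its propanoyl-type chain on the ring nitrogen, gives only > 100000 nM, a limit. The other two values shown stand at the same limit, (the limit of > 100000 nM in this assay, at which 3 of the 3 values shown sit), so compound 3 cannot be placed relative to them.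

Compound 4 is `Cc1nn(C(=O)C2CCCCC2)c(N)c1-c1ccc(Cl)c(Cl)c1`, not yet measured. It differs from compound 3 by cyclohexyl in place of propyl on a carbonyl carbon. Within the data shown here, the only measured step, a step that the two limits leave unreadable from compound 1 to compound 2, concerns an aromatic substituent and is itself unreadable, so no step bears on this change. No effect beyond the scatter in this assay can therefore be expected, though a larger ring is sometimes tolerated.

Compound 4 is expected to give 150000 nM, within 30000 nM to 1000000 nM, a step that the limit leaves unreadable from compound 3 to compound 4, most likely again reported only as a limit.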

Compound 4, half-maximal inhibitory concentration: 3300 nM
Beside the measured number, compound 4's estimate is 45-fold (1.66 log units) above it; measured number outside the range, below it.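

In this assay, the group on the carbonyl carbon at the aromatic nitrogen turns out to matter: cyclohexyl in place of propyl gives an at least 30-fold lower number from compound 3 to compound 4 (1.48 log units; beyond the scatter). The change adds a six-membered non-aromatic ring of carbon only and no hydrogen-bond donors or acceptors, so a readable value here needs neither. Compound 4 is the only compound shown with a number and not a limit: the limit of > 100000 nM in this assay, at which 3 of the 4 values shown sit.

The compounds shown leave open whether the ring itself or only the larger carbon group carries the step, which a straight hexyl chain would separate. As far as these compounds go, how a phenyl or a piperidine in the same place would compare also remains open.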